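Lengthening the Hydroxyl Chain on a Shared Core

The source may hold more compounds than are shown below. What is called first, only, known or untested is meant among the compounds shown, and "the series" means these compounds.

The three measured compounds share one core and differ only in the group on a saturated chain carbon bound to an aromatic nitrogen. Compound 1 `OCCn1nc(-c2cc3ccccc3[nH]2)nc1SCc1ccccc1` carries a 2-hydroxyethyl there, compound 2 `C=CCn1nc(-c2cc3ccccc3[nH]2)nc1SCc1ccccc1` an allyl group, and compound 3 `c1ccc(CSc2nc(-c3cc4ccccc4[nH]3)n(Cc3ccccc3)n2)cc1` a benzyl. In a functional assay on MCF7 cells (Homo sapiens) for antiproliferative activity, read by sulforhodamine B assay, with a stated time of 48 h (on this read-out higher numbers stand for weaker inhibition and lower numbers for stronger inhibition), compound 1 gives 14.6 ug/mL, compound 2 gives 15.5 ug/mL, and compound 3 gives 14.8 ug/mL. Compound 3 thus stands second highest of the three numbers, yet all three lie within the scatter of one another, so no ordering among them can be read.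

Compound 4 `OCCCn1nc(SCc2ccccc2)nc1-c1cc2ccccc2[nH]1` arises from compound 3 by one change: 2-hydroxyethyl in place of phenyl on a saturated chain carbon bound to an aromatic nitrogen. Within the data shown here, the only measured step of a similar kind, a 1.1-fold higher number from compound 1 to compound 2 (0.03 log units; within the scatter), exchanged one group for another on a saturated chain carbon bound to an aromatic nitrogen and did not move the number beyond the scatter. Likewise compound 1 and compound 3, a hydroxyl-bearing chain against a benzyl, show essentially the same values. Nothing among these compounds suggests that the group at this position shifts the read-out. For compound 4 the expected step is therefore a 1.0-fold higher number from compound 3 to compound 4 (0.01 log units; within the scatter), none beyond the scatter. The estimate for compound 4 in this assay is 15 ug/mL, within a range from 8 ug/mL to 28 ug/mL.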

Compound 4, half-maximal inhibitory concentration: 16.2 ug/mL
Compound 4: the middle estimate sits 1.1-fold (0.03 log units) below what was measured, within the range that was stated.
By their numbers in this assay, from the lowest: compounds 1, 3, 2 and 4 (each within the scatter of the next).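

Compound 4 loses an aromatic ring altogether, the phenyl of six carbon atoms, and gains an open 2-hydroxyethyl that brings one hydrogen-bond donor and one hydrogen-bond acceptor, yet in this assay the result is a 1.1-fold higher number from compound 3 to compound 4 (0.04 log units; within the scatter) and nothing more. Read one bond further out, this is benzyl exchanged for 3-hydroxypropyl, so on a saturated chain carbon bound to an aromatic nitrogen, a change that removes the ring and adds a hydroxyl leaves the number inside the ordinary spread of repeat measurements, which is a broader test of this position than the earlier compounds gave. No measurement among those at hand offers an explanation for this flat result.

Every group seen so far at this position is uncharged, so a dimethylamino group or a carboxylic acid at the end of the chain, or a much longer chain such as octyl, could still behave differently. The compounds shown also hold the rest of the shared core fixed, so they cannot tell whether the read-out responds to changes elsewhere, such as replacing the benzyl group on sulfur with methyl.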